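The source may report more compounds than this note shows. Statements on the series, on what has been measured and on what is new or still open speak of the compounds shown alone.

Measured compounds in the series:
- compound 1 `Cc1ccccc1CN1CCc2c(sc(NC(=O)c3ccccc3Cl)c2C(N)=O)C1`: > 50000 nM
- compound 2 `N#Cc1ccccc1CN1CCc2c(sc(NC(=O)c3ccccc3Cl)c2C(N)=O)C1`: > 50000 nM
- compound 3 `NC(=O)c1c(NC(=O)c2ccccc2Cl)sc2c1CCN(C(=S)Nc1ccccc1)C2`: 46700 nM

In a functional assay on HeLa cells (Homo sapiens) for antiproliferative activity, with a stated time of 24 h (a lower number here means a stronger inhibitor, a higher number a weaker inhibitor), compound 1 gives only a limit of the assay, > 50000 nM. Compound 2 likewise gives only a limit in this assay, > 50000 nM. Among the compounds with values here, compound 3 is the one compound with a number in this assay, 46700 nM; it stands at the weak end of what the assay reports. The two other values are limits, as the summary shows: the limit of > 50000 nM in this assay, at which 2 of the 3 values shown sit. The step from compound 1 to compound 2, a step that the two limits leave unreadable from compound 1 to compound 2, cannot be read. The two steps that reach compound 3 are an at least 1.0-fold lower number from compound 1 to compound 3 (0.02 log units; that floor lies within the scatter) and an at least 1.0-fold lower number from compound 2 to compound 3 (0.02 log units; that floor lies within the scatter); both are floors that lie within the scatter.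

Compound 4 `NC(=O)c1c(NC(=O)c2ccccc2Cl)sc2c1CCN(C(=S)Nc1ccccc1-c1ccccc1)C2` is not yet measured. It differs from compound 3 by phenyl in place of hydrogen on an aromatic carbon. Within the data shown here, no measured step exchanges a hydrogen for a phenyl on that ring, so nothing among the three compounds bears on this change directly. All three measured values sit at or near the weak end of the assay, and the one readable direction is a floor within the scatter. The expected step from compound 3 to compound 4 is therefore a 1.2-fold lower number from compound 3 to compound 4 (0.07 log units; within the scatter), a change not beyond the scatter. Compound 4 is thus estimated at 40000 nM, with a range from 12000 nM to 100000 nM, and a sizeable chance that only a limit is reported.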

Compound 4, half-maximal inhibitory concentration: 24000 nM
Estimate against measurement, compound 4: 1.7-fold (0.22 log units) above, within the range that was stated.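

Working notes on the series. In this assay, phenyl in place of hydrogen on an aromatic carbon, ortho to a large group, gives a 1.9-fold lower number from compound 3 to compound 4 (0.29 log units; within the scatter), so compound 3 and compound 4 cannot be told apart. This is the only step shown with a number at both ends, and it shows that this position can carry phenyl, the change from phenyl to 2-phenylphenyl, while the read-out remains a number rather than a limit. The series as a whole still leans on a limit, and the other values give little to set this step against: the limit of > 50000 nM in this assay, at which 2 of the 4 values shown sit.

Going by these compounds, the step between the two compounds that stand at that limit cannot be read, and whether any substituent at this position moves the read-out beyond the scatter remains open. Only hydrogen and phenyl appear on this carbon, so a methoxy group, an amine or a carboxylic acid there, or phenyl on another carbon of the same ring, would be needed to say whether this position matters at all.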